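The compounds below may be only part of what the source reports. "The series", "measured", "known", "first", "only" and "open" are said of these compounds alone.

Compound 1 `Cc1cn([C@@H]2O[C@@H]3COC(=O)[C@]3(OS(C)(=O)=O)[C@H]2O)c(=O)[nH]c1=O` and compound 2 `COC(=O)NC1=CS(=O)(=O)O[C@@]12[C@@H](CO[Si](C)(C)C(C)(C)C)O[C@@H](n1cc(C)c(=O)n(C)c1=O)[C@@H]2O[Si](C)(C)C(C)(C)C` share a bicyclic nucleoside framework built on the same sugar-derived core. In a functional assay on MT4 cells (Homo sapiens) (on this read-out lower numbers stand for higher toxicity in this test and higher numbers for lower toxicity in this test), compound 1 reaches only a limit of >= 250000 nM, so no number is known for it. Among the compounds with values here, compound 2 is therefore the only compound with a measured number: in this assay compound 2 gives 29900 nM, while the other value shown is the limit of >= 250000 nM in this assay, at which 1 of the 2 values shown sits. Compound 3 `Cc1cn([C@@H]2O[C@H](CO[Si](C)(C)C(C)(C)C)[C@@]3(OS(=O)(=O)C=C3NCC(=O)C(N)=O)[C@H]2O[Si](C)(C)C(C)(C)C)c(=O)n(C)c1=O` is not yet measured and differs from compound 2 in one place: (carbamoylcarbonyl)methyl in place of methoxycarbonyl on an amine nitrogen. Within the data shown here, with no step between two measured compounds to lean on, the expected change from compound 2 to compound 3 is a 1.3-fold higher number from compound 2 to compound 3 (0.13 log units; within the scatter), a shift toward lower toxicity that is small and may not exceed the usual scatter. For compound 3 the estimated half-maximal cytotoxic concentration in this assay is 40000 nM, with a range from 12000 nM to 150000 nM.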

Compound 3, half-maximal cytotoxic concentration: 9590 nM
Compound 3: middle estimate off by 4.2-fold (0.62 log units), on the high side; measured number below the stated range.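

Within the data shown here, on the amine nitrogen whose other neighbour is the double-bonded ring carbon, the earlier compounds offered no step to read. In this assay, (carbamoylcarbonyl)methyl in place of methoxycarbonyl now gives a 3.1-fold lower number from compound 2 to compound 3 (0.49 log units; beyond the scatter) and so moves the read-out toward higher toxicity, which shows that the group on this nitrogen matters in this test, although this is a single step and no pattern. Nothing shown gives a measured cause for this shift.

The compounds shown leave open whether the shift follows from the loss of methoxycarbonyl or from the arrival of (carbamoylcarbonyl)methyl, as one exchange cannot separate the two. They also leave open how a free amine, an acetyl group or a carboxylic acid-bearing chain on the same nitrogen would read.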